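Methyl to Methoxy on Two Cores in a Cell Assay

The compounds below may be only part of what the source reports. "The series", "measured", "known", "first", "only" and "open" are said of these compounds alone.

Measured compounds:
- compound 1 `COC(=O)CNC(=O)c1ccc(OC[C@@H]2COc3ccccc3O2)cc1-c1ccccc1C`: 700 nM
- compound 2 `COC(=O)CNC(=O)c1ccc(OC[C@@H]2COc3ccccc3O2)cc1-c1ccccc1OC`: 35000 nM
- compound 3 `COC(=O)[C@H](CCSC)NC(=O)c1ccc(C(=O)NC[C@H]2COc3ccccc3O2)cc1-c1ccccc1C`: 87000 nM

In a functional assay (HSMC cells, Homo sapiens) for antiproliferative activity, with a stated time of 72 h (on this read-out higher numbers stand for weaker inhibition and lower numbers for stronger inhibition), compound 1 gives 700 nM. Compound 2 differs from it by a single change, (methoxy in place of methyl on an aromatic carbon), and this change gave a 50-fold higher number from compound 1 to compound 2 (1.70 log units; beyond the scatter). Compound 3 stands on a different core, and the difference between the two cores is not broken down here; in this assay compound 3 gives 87000 nM, the highest of the three numbers and far from compound 1.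

Compound 4 `COC(=O)[C@H](CCSC)NC(=O)c1ccc(C(=O)NC[C@H]2COc3ccccc3O2)cc1-c1ccccc1OC` is not yet measured. It carries the same change relative to compound 3 as compound 2 carries relative to compound 1: methoxy in place of methyl on an aromatic carbon. The place of the change is described in the same words for both pairs, so this is the same change on a second core. Going by the values given here, the only guide to its size is the earlier step, a 50-fold higher number from compound 1 to compound 2 (1.70 log units; beyond the scatter), which was large. Because compound 3 already gives 87000 nM, a step of similar size would place compound 4 at a very weak level of inhibition in this assay. On that basis the step is expected to be a 4.6-fold higher number from compound 3 to compound 4 (0.66 log units; beyond the scatter). For compound 4 the expected value in this assay is 400000 nM, with a range from 87000 nM to 4000000 nM.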

Compound 4, half-maximal inhibitory concentration: 252000 nM
Compound 4: middle estimate off by 1.6-fold (0.20 log units), on the high side; the measured number falls inside the stated range.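

Replacing the methyl with methoxy, which turns 2-methylphenyl into 2-methoxyphenyl, gives a 2.9-fold higher number from compound 3 to compound 4 (0.46 log units; beyond the scatter) in this assay, so the number rises on the second core as it did on the first. The direction of the step therefore carries over between these two cores, but its size does not: the same change on two cores in this assay, a 50-fold higher number (1.70 log units; beyond the scatter) from compound 1 to compound 2 and a 2.9-fold higher number (0.46 log units; beyond the scatter) from compound 3 to compound 4, 17-fold (1.24 log units) apart, beyond the scatter of two such steps These two pairs do not show which part of the cores sets the size of the step, as the cores differ in a way not broken down here, so a step measured on one core gives only a rough guide to its size on the other.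

Going by these compounds, it remains open how a group such as ethyl, chloro or hydroxyl at the same place on the ring would compare with methyl and methoxy on each core. On these data alone, it is also open whether the same change would behave alike if a carboxylic acid replaced the ester on either core, or on a third core.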